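A Urea-to-Amide Change on Compound 1

This account rests on a few compounds, and the source may have more. Where it says the series, first, only, none or still open, it means among the compounds named here.

In a functional assay on T47D cells (Homo sapiens) for inhibition, read by sulforhodamine B assay, with a stated time of 48 h (on this read-out lower numbers stand for stronger inhibition of growth and higher numbers for weaker inhibition of growth), compound 1 `COc1cc(-c2nn(-c3cccc(NC(=O)Nc4ccc(Cl)c(Cl)c4)c3)cc2-c2ccncc2)ccc1Cl` gives 1420 nM, level with compound 2 `O=C(Nc1cccc(-n2cc(-c3ccncc3)c(-c3ccc(Cl)c(O)c3)n2)c1)Nc1ccc(Cl)c(Cl)c1` at 1550 nM. Compound 3 `COc1cc(-c2nn(-c3cccc(NC(=O)c4ccc(Cl)c(C(F)(F)F)c4)c3)cc2-c2ccncc2)ccc1Cl` carries one change from compound 1: 4-chloro-3-(trifluoromethyl)phenyl in place of (3,4-dichlorophenyl)amino on a carbonyl carbon. This places 4-chloro-3-(trifluoromethyl)phenyl in place of (3,4-dichlorophenyl)amino on a carbonyl carbon. Going by the values given here, the only measured step, a 1.1-fold higher number from compound 1 to compound 2 (0.04 log units; within the scatter), concerns hydrogen in place of methyl on an oxygen on an aromatic ring, a different change, so it offers no direct guide. No shift beyond the scatter is therefore expected in this assay, and the estimated move is a 1.0-fold lower number from compound 1 to compound 3 (0.01 log units; within the scatter). Compound 3 is expected at 1400 nM, within an estimated range of 450 nM to 4400 nM.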

Compound 3, concentration for 50% growth inhibition: 2050 nM
Compound 3: middle estimate off by 1.5-fold (0.17 log units), on the low side; low and high end bracket the measured number.
By their numbers in this assay, from the lowest: compounds 1, 2 and 3 (each within the scatter of the next).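

The step at this carbonyl carbon, a 1.4-fold higher number from compound 1 to compound 3 (0.16 log units; within the scatter), shows that in this assay the urea of compound 1 can become the amide of compound 3 with no shift beyond the scatter, although the hydrogen-bond donor of the leaving group is lost. Going by these compounds alone, the earlier step touched only the methyl on an oxygen, so this is the first reading at this end of the molecule. No supporting data bear on why the values stay level. The compounds shown change the amino link and the ring substituents together, leaving their separate contributions open. They also leave open whether an amine or a carboxylic acid in place of 4-chloro-3-(trifluoromethyl)phenyl would hold the value.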